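Piperazine nitrogen substituent change in the dithiocarbamate benzamide series

The source may report more compounds than this note shows. Statements on the series, on what has been measured and on what is new or still open speak of the compounds shown alone.

Compound 2 `CN1CCN(C(=S)SCc2ccc(C(=O)Nc3ccccc3N)cc2)CC1` and compound 1 `Nc1ccccc1NC(=O)c1ccc(CSC(=S)N2CCN(Cc3ccncc3)CC2)cc1` share one core and differ only in the group on a saturated chain carbon bound to the ring nitrogen. In a functional assay on HeLa cells (Homo sapiens) for antiproliferative activity, read by CCK-8 assay, with a stated time of 72 h, tested at 2 uM (a lower number here means a weaker effect, a higher number a stronger effect of the compound at the concentration tested), compound 1 gives 59.5%, and in this assay compound 2 gives 52.6%. Compound 2 has the lower of the two numbers, but the gap is a number 6.9 percentage points lower from compound 1 to compound 2 (within the scatter), so the two values are not separated.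

Compound 3 `Nc1ccccc1NC(=O)c1ccc(CSC(=S)N2CCN(c3ccncc3)CC2)cc1` is to be measured in this assay. It differs from compound 2 by pyridin-4-yl in place of methyl on an amine nitrogen in a ring. Going by the values given here, the only step measured so far, a number 6.9 percentage points lower from compound 1 to compound 2 (within the scatter), also concerns the presence or absence of a pyridin-4-yl on the basic nitrogen side of the core, though there it sat on a chain carbon rather than directly on the ring nitrogen. That step stayed within the scatter, and no other comparison is available.

For compound 3 a step of a number 3.4 percentage points higher from compound 2 to compound 3 (within the scatter) is therefore expected, one that does not rise beyond the scatter. Compound 3 is estimated at 56%, within a range of 40% to 70%.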

Compound 3, a percentage reported as inhibition, at one concentration (the size of the read-out at that concentration, not a potency): 77%
Estimate against measurement, compound 3: 21 percentage points below; measured number above the stated range.
By their numbers in this assay, from the lowest: compounds 2 and 1 (each within the scatter of the next); then compound 3.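

Working notes: in this assay, this position on the amine nitrogen in the ring now gives a step beyond the scatter, with pyridin-4-yl in place of methyl giving a number 24.4 percentage points higher from compound 2 to compound 3 (beyond the scatter). The attachment matters as well as the group itself: the direct pyridin-4-yl also stands clear of the (pyridin-4-yl)methyl group, with a number 17.5 percentage points higher from compound 1 to compound 3 (beyond the scatter), while the change between that group and methyl stayed small, with a number 6.9 percentage points lower from compound 1 to compound 2 (within the scatter). Among these three compounds, the higher number therefore goes only with the aromatic ring bound directly to the nitrogen, and no measurement available here explains this difference.

On these data alone, whether the pyridine nitrogen takes part remains open, since a phenyl or a pyridin-3-yl group on the same nitrogen could either keep or lose the higher number, and a longer chain carrying pyridin-4-yl would test the attachment further. The read-out is also an inhibition at a single concentration, so it leaves the potency of the three compounds open, along with whether the same order holds in cells other than those of this assay.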